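Benzisothiazolyl oxadiazole series: replacing the aryl group

The compounds below may be only part of what the source reports. "The series", "measured", "known", "first", "only" and "open" are said of these compounds alone.

Measured so far:
compound 1, `c1ccc(-c2nnc(-c3nsc4ccccc34)o2)cc1`, 60%
compound 2, `Clc1ccc(-c2nnc(-c3nsc4ccccc34)o2)cc1`, 13%

Compound 2 stands lowest of the two numbers in a functional assay on the whole organism for inhibition, with Rattus norvegicus as the target, with a stated time of 2 h, at a dose of 100 mg/kg by the oral route; a lower number here means less inhibition, a higher number more inhibition at the dose given (going by the name of the read-out). Among the compounds with values here, the single measured step, a number 47 percentage points lower from compound 1 to compound 2 (beyond the scatter), is the only one in the set. Compound 3, `CNc1nnc(-c2nsc3ccccc23)o1`, has not been measured. The change from compound 2 to compound 3 is methylamino in place of 4-chlorophenyl on an aromatic carbon. Within the data shown here, the one measured step concerns a chloro substituent on the phenyl ring, and that ring leaves entirely in compound 3, so that step does not bear directly on the new change; it shows only that the read-out in this assay moved by a large amount on a small change at that end of the molecule. Among the measured compounds shown here, no measured compound carries a methylamino group on the core. The direction of the step for compound 3 is therefore open, and the expectation rests on compound 2 being the low end of a set whose other member, compound 1, gives 60%. Compound 3 is estimated at 30%, within 5% to 65%, an expected step of a number 17 percentage points higher from compound 2 to compound 3 (beyond the scatter).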

Compound 3, a percentage reported as inhibition, in the whole organism at one dose (the size of the read-out at that dose, not a potency): 10%
For compound 3 the middle estimate is 20 percentage points above the measured one, and the stated range covers the measured number.
By their numbers in this assay, from the lowest: compounds 3 and 2 (each within the scatter of the next); then compound 1.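

Working notes on the aryl position: in this assay, methylamino in place of 4-chlorophenyl on this aromatic carbon gives a number 3 percentage points lower from compound 2 to compound 3 (within the scatter), so compound 3, with no ring in this group and with a hydrogen-bond donor, cannot be told apart from compound 2 despite the loss of 7 heavy atoms in exchange for 2. Against the unsubstituted phenyl group, the same methylamino group gives a number 50 percentage points lower from compound 1 to compound 3 (beyond the scatter), and among the three compounds the higher read-out now belongs to compound 1 alone, with two very different replacements at this position each standing far beneath it. No supporting data bear on why these groups give these read-outs.

The compounds shown leave open whether the phenyl ring itself carries the effect in this assay or whether another ring, such as pyridine or cyclohexyl, or a smaller phenyl substituent such as fluoro, would hold the read-out near that of compound 1. They also leave open how a larger amine such as morpholine or a longer chain such as butylamino would behave on this carbon, and each read-out here comes from one dose only.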